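Shorter hydroxyalkyl chain on the thioether of compound 1

A few compounds are considered here, and "the series" means these few. Any claim that something is new, unique, unknown or untested is made for them only; others in the source may bear on it.

Compound 1 `CC1=C(SCCCCO)C(=O)c2ccccc2C1=O` carries a 4-hydroxybutyl chain on sulfur. In a functional assay on WI-38 cells (Homo sapiens) for inhibition (a lower number here means a stronger inhibitor, a higher number a weaker inhibitor), compound 1 gives > 10000 nM, which is a limit of the assay rather than a number, so its standing on the scale is unresolved. Compound 2 `CC1=C(SCCCCCCO)C(=O)c2ccccc2C1=O` is the chain-extended analogue. In this assay compound 2 gives > 10000 nM, again a limit and not a number. Within the data shown here, the step that the two limits leave unreadable from compound 1 to compound 2 is therefore not readable in size, and the one piece of evidence is the limit of > 10000 nM in this assay, at which 2 of the 2 values shown sit.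

Compound 3 `CC1=C(SCC(C)O)C(=O)c2ccccc2C1=O` goes the other way along the chain: 1-hydroxyethyl in place of 3-hydroxypropyl on a saturated chain carbon bound to a sulfur. Among the measured compounds shown here, no measured step covers a shortening of this chain, and the only measured step, which lengthens it, gives no readable size. Two limits on either side of compound 1 leave no trend to lean on. For compound 3 the step that the limit leaves unreadable from compound 1 to compound 3 is expected to stay within the scatter, with a limit the most likely outcome. The estimate for compound 3 is 15000 nM, with a range from 4000 nM to 60000 nM.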

Compound 3, half-maximal inhibitory concentration: 5060 nM
Estimate against measurement, compound 3: 3.0-fold (0.47 log units) above; low and high end bracket the measured number.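

Among these compounds, compound 3, carrying (2-hydroxypropyl)sulfanyl where compound 1 carries (4-hydroxybutyl)sulfanyl, gives the only number so far, which places this chain on the scale of this assay for the first time. As far as these compounds go, the steps read an at least 1.9-fold lower number from compound 1 to compound 3 (0.29 log units; that floor lies within the scatter) and an at least 1.9-fold lower number from compound 2 to compound 3 (0.29 log units; that floor lies within the scatter), and both are floors set by limits, so the true size of each step remains unknown and neither establishes a difference beyond the scatter by itself. The two longer straight chains remain unresolved, and the change at this place can be described only against limits: the limit of > 10000 nM in this assay, at which 2 of the 3 values shown sit.

The compounds shown do not separate the effect of shortening the chain from that of moving the hydroxy group onto a branched carbon, a question that a straight 2-hydroxyethyl chain on sulfur would address directly. Also open, from the compounds shown here alone, is whether the hydroxy group matters at all, which an unsubstituted propyl chain, or an amine or a carboxylic acid in its place, would test.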